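Alkyne-linked phenoxyacetic acids: sulfone to sulfonamide

The compounds below may be only part of what the source reports. "The series", "measured", "known", "first", "only" and "open" are said of these compounds alone.

Compound 1 `O=C(O)COc1cc(F)ccc1C#Cc1ccccc1Cl` in an assay on CHO cells for displacement of a labelled ligand from prostaglandin D2 receptor 2 (Homo sapiens), read by scintillation counting (a higher number here means a weaker inhibitor, a lower number a stronger inhibitor), gives 4780 nM. Compound 2 `Cc1ccc(S(=O)(=O)Cc2ccccc2)cc1C#Cc1cc(Cl)ccc1OCC(=O)O` gives 5 nM in this assay, the lower of the two numbers; the gap to compound 1 lies beyond the scatter. Compound 3 `COCCNS(=O)(=O)c1ccc(C)c(C#Cc2cc(Cl)ccc2OCC(=O)O)c1` differs from compound 2 by (2-methoxyethyl)amino in place of benzyl on a sulfonyl sulfur. Among the compounds with values here, no measured step of this kind exists among the pair, so the size of the change rests on the structural difference alone; a modest move toward a higher number in this assay is expected, though a result within the scatter cannot be excluded. The estimated step is a 4.0-fold higher number from compound 2 to compound 3 (0.60 log units; beyond the scatter). Compound 3 is expected to give 20 nM, within 4 nM to 120 nM.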

Compound 3, inhibition constant: 3.6 nM
Compound 3: the middle estimate sits 5.6-fold (0.74 log units) above what was measured; the whole stated range lies above it.
By their numbers in this assay, from the lowest: compounds 3 and 2 (each within the scatter of the next); then compound 1.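

With (2-methoxyethyl)amino in place of benzyl on a sulfonyl sulfur, a 1.4-fold lower number from compound 2 to compound 3 (0.14 log units; within the scatter) in this assay shows that this position accepts an open chain with a hydrogen-bond donor and acceptor in place of an aromatic ring. For this pair, a low number therefore does not depend on the benzyl ring. Nothing measured explains this result. Still open, going by these compounds, is how a smaller methylamino or a dimethylamino group, without the nitrogen hydrogen, would compare. On these data alone, a longer chain ending in a carboxylic acid or an amine is equally open.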